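Benzoxazole in place of chlorophenyl: expectation for compound 4

A few compounds are considered here, and "the series" means these few. Any claim that something is new, unique, unknown or untested is made for them only; others in the source may bear on it.

Of the compounds shown here, three have been tested in an assay on CHO cells for displacement of a labelled ligand from prostaglandin E2 receptor EP1 subtype (Mus musculus), read by scintillation counting, with a stated time of 20 min; on this read-out higher numbers stand for weaker inhibition and lower numbers for stronger inhibition. Compound 1 `O=C(O)CCCSCCN1C(=O)CC[C@@H]1/C=C/[C@@H](O)Cc1cccc(-c2nc3ccccc3s2)c1` gives > 10000 nM, which is a limit of the assay and not a number. Compound 2 `O=C(O)CCCSCCN1C(=O)CC[C@@H]1/C=C/[C@@H](O)Cc1cccc(-c2cc3ccccc3o2)c1` likewise gives > 10000 nM, again a limit. The step that the two limits leave unreadable from compound 1 to compound 2 is therefore unreadable; both carry the same bicyclic heteroaryl type that compound 4 receives, but a different acid tail. Among the measured compounds shown here, compound 3 `O=C(O)c1csc(SCCN2C(=O)CC[C@@H]2/C=C/[C@@H](O)Cc2cccc(-c3ccc(Cl)cc3)c2)n1` is the only one with a number, 6300 nM in this assay. Compound 4 `Cc1cc(C)c2oc(-c3cccc(C[C@H](O)/C=C/[C@H]4CCC(=O)N4CCSc4nc(C(=O)O)cs4)c3)nc2c1` differs from compound 3 by 5,7-dimethyl-1,3-benzoxazol-2-yl in place of 4-chlorophenyl on an aromatic carbon. For the measured compounds named here, no measured step bears directly on this change; the only guide is the limit of > 10000 nM in this assay, at which 2 of the 3 values shown sit. A step toward weaker inhibition is expected, a 1.9-fold higher number from compound 3 to compound 4 (0.28 log units; within the scatter), so compound 4 is estimated at 12000 nM, between 3000 nM and 50000 nM, with a fair chance of a limit only.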

Compound 4, inhibition constant: 3200 nM
Beside the measured number, compound 4's estimate is 3.8-fold (0.57 log units) above it; the range from low to high includes it.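

In this assay, 5,7-dimethyl-1,3-benzoxazol-2-yl in place of 4-chlorophenyl gives a 2.0-fold lower number from compound 3 to compound 4 (0.29 log units; within the scatter), so this aromatic carbon, meta to a large group, does not separate the two groups. The entering group adds a second aromatic ring and two hydrogen-bond acceptors, yet compound 4 still gives a number. Two of the values shown remain limits and not numbers: the limit of > 10000 nM in this assay, at which 2 of the 4 values shown sit.

Open, going by these compounds, is what the two methyl groups contribute, and whether an amine or a longer chain on the benzoxazole ring would move the number beyond the scatter.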